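The source may hold more compounds than are shown below. What is called first, only, known or untested is meant among the compounds shown, and "the series" means these compounds.

Of the compounds shown here, two share one core and have been measured. Compound 2 `CN1C(=O)C(c2cccc(F)c2)N(C)c2nc(Nc3ccc(S(N)(=O)=O)cc3)ncc21` gives 134 nM in an assay on Sf9 cells for inhibition of serine/threonine-protein kinase 4 (Homo sapiens), read by luminescence and ADP-Glo, with a stated time of 1 h, in the presence of a further agent that is not named here (a higher number here means a weaker inhibitor, a lower number a stronger inhibitor), and compound 1 `CC(C)CC1C(=O)N(C)c2cnc(Nc3ccc(S(N)(=O)=O)cc3)nc2N1C` gives 77 nM in this assay; the two are separated by a 1.7-fold higher number from compound 1 to compound 2 (0.24 log units; within the scatter). Compound 3 `CN1C(=O)C(c2ccccc2Cl)N(C)c2nc(Nc3ccc(S(N)(=O)=O)cc3)ncc21` differs from compound 2 in one place: 2-chlorophenyl in place of 3-fluorophenyl on a saturated ring carbon. For the measured compounds named here, only one measured step bears on this, the swap of an isobutyl group for a 3-fluorophenyl group, and it stayed within the scatter, so no change beyond the scatter is expected here. Compound 3 is therefore estimated at 150 nM in this assay, with a range from 60 nM to 400 nM. Compound 3 is thus expected to show a step of a 1.1-fold higher number from compound 2 to compound 3 (0.05 log units; within the scatter).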

Compound 3, half-maximal inhibitory concentration: 129 nM
Compound 3: middle estimate off by 1.2-fold (0.07 log units), on the high side; low and high end bracket the measured number.
By their numbers in this assay, from the lowest: compounds 1, 3 and 2 (each within the scatter of the next).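

Exchanging 3-fluorophenyl for 2-chlorophenyl on this saturated ring carbon gives a 1.0-fold lower number from compound 2 to compound 3 (0.02 log units; within the scatter) in this assay and shows that a different halogen, at a different ring position, leaves the number within the scatter. Compared with isobutyl, 2-chlorophenyl gives a 1.7-fold higher number from compound 1 to compound 3 (0.22 log units; within the scatter) and so also stays within the scatter, which makes three groups at this carbon that cannot be told apart. No measurement here gives a reason for this. On these data alone, whether a methyl group, an amine or a carboxylic acid at this carbon would also stay within the scatter remains open.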